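Replacing an Ester by an Amide on the Side Arm

The compounds below may be only part of what the source reports. "The series", "measured", "known", "first", "only" and "open" are said of these compounds alone.

Three measured compounds share one core and differ only in the group on a single aromatic carbon. Compound 1 `COC(=O)/C=C/c1cccc(N(Cc2ccc(-c3ccc(F)c(Cl)c3)cc2)C(=O)C2CCCCC2)c1` carries a 3-chloro-4-fluorophenyl there, and in an assay on isolated protein with Bile acid receptor (Homo sapiens) as the target (a higher number here means that more compound is needed for the effect, a lower number that less compound is needed), compound 1 gives 66 nM. Compound 2 `COC(=O)/C=C/c1cccc(N(Cc2ccccc2)C(=O)C2CCCCC2)c1` has hydrogen in that place; in this assay compound 2 reaches only the limit of the assay, > 1000 nM. Compound 3 `COC(=O)/C=C/c1ccc(CN(C(=O)C2CCCCC2)c2cccc(/C=C/C(=O)OC)c2)cc1` carries a 2-(methoxycarbonyl)ethenyl there; in this assay compound 3 also stands at the limit, > 1000 nM, so no number is known for it. Both steps away from compound 1 were large losses, an at least 15-fold higher number from compound 1 to compound 2 (1.18 log units; beyond the scatter) and an at least 15-fold higher number from compound 1 to compound 3 (1.18 log units; beyond the scatter), whereas a step that the two limits leave unreadable from compound 2 to compound 3 because of the limit of > 1000 nM in this assay, at which 2 of the 3 values shown sit.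

Compound 4 `COC(=O)/C=C/c1cccc(N(Cc2ccc(/C=C/C(=O)NC(C)(C)C)cc2)C(=O)C2CCCCC2)c1` is compound 3 with one change: (tert-butyl)amino in place of methoxy on a carbonyl carbon. Going by the values given here, none of the measured steps touches this carbonyl; each of them swaps the whole group on the aromatic carbon, and the only step between the two limit-bound compounds cannot be read. The expected step that the limit leaves unreadable from compound 3 to compound 4 is therefore put near zero, with wide uncertainty. For compound 4 the estimate in this assay is 2000 nM, within a range from 400 nM to 10000 nM, most probably reported again only as a limit.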

Compound 4, half-maximal effective concentration: > 1000 nM
Compound 4 was reported as a limit; the forecaster's own chance of this, stated with the estimate: 70%; the middle value does not contradict the limit.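

Compound 4 gives > 1000 nM in this assay, and this is a limit of the assay, not a number. With 2-((tert-butyl)carbamoyl)ethenyl on this aromatic carbon, the core still does not return to the level that the 3-chloro-4-fluorophenyl gives, and the change in that group leaves an at least 15-fold higher number from compound 1 to compound 4 (1.18 log units; beyond the scatter). So a second side arm built on a carbonyl, now with (tert-butyl)amino in place of methoxy and with a hydrogen-bond donor that the methoxy lacks, also stays out of the readable range, but the steps among compound 2, compound 3 and compound 4 cannot be read, because all three rest on the same boundary: the limit of > 1000 nM in this assay, at which 3 of the 4 values shown sit.

Going by these compounds, whether the amide of compound 4 is better than, worse than or equal to the ester of compound 3 therefore stays open. Also open, on these data alone, is whether a smaller group on this carbonyl carbon, such as a plain amino group or the hydroxyl of a carboxylic acid, or a phenyl ring with other halogens on the aromatic carbon, would give a value that can be read as a number.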